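The source may report more compounds than this note shows. Statements on the series, on what has been measured and on what is new or still open speak of the compounds shown alone.

Measured so far in a functional assay on HEK293 cells for agonist activity at Vasopressin V2 receptor (Homo sapiens), read by a luciferase reporter and cAMP accumulation; a higher number here means that more compound is needed for the effect, a lower number that less compound is needed:
compound 1, `Cc1cc(C(=O)N2CCCCc3ccccc32)ccc1CNC(=O)NCC(=O)OC(C)(C)C`, gives 120 nM;
compound 2, `Cc1cc(C(=O)N2CCCCc3ccccc32)ccc1CNC(=O)N1CCC[C@H]1C(=O)OC(C)C`, gives 950 nM.

Of these two numbers, compound 2 has the higher one, so more of compound 2 is needed for the same effect in this assay than of compound 1, and the gap between them, a 7.9-fold higher number from compound 1 to compound 2 (0.90 log units; beyond the scatter), is larger than the usual scatter.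

Compound 3, `Cc1cc(C(=O)N2CCCCc3ccccc32)ccc1CNC(=O)N1CC(=O)C[C@H]1C(=O)N(C)C`, is the next compound. It keeps the shared core of compound 2 and alters only the ring attached to the urea carbonyl: 2-(dimethylcarbamoyl)-4-oxopyrrolidin-1-yl in place of 2-(isopropoxycarbonyl)pyrrolidin-1-yl on a carbonyl carbon. The ester becomes an amide, and the ring gains a ketone.

Going by the values given here, only one measured step exists, from compound 1 to compound 2, and it changed the whole group rather than the ester alone, so it speaks only indirectly to this change. It shows that compound 3 starts from the weaker of the two measured compounds, and nothing in the data points clearly in either direction for the ester-to-amide and ketone change. The step to compound 3 is therefore expected to stay within the scatter, a 1.3-fold higher number from compound 2 to compound 3 (0.10 log units; within the scatter). Compound 3 is estimated at 1200 nM, in a range from 300 nM to 5000 nM.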

Compound 3, half-maximal effective concentration: 27 nM
For compound 3 the middle estimate is 44-fold (1.65 log units) above the measured one; the whole stated range lies above it.
By their numbers in this assay, from the lowest: compound 3; then compound 1; then compound 2.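

Going by these compounds alone, the group on the carbonyl carbon matters much more than the first pair of compounds could show: in this assay, replacing 2-(isopropoxycarbonyl)pyrrolidin-1-yl with 2-(dimethylcarbamoyl)-4-oxopyrrolidin-1-yl gives a 35-fold lower number from compound 2 to compound 3 (1.55 log units; beyond the scatter), although both groups have the same number of heavy atoms and the same five-membered ring. The new group also compares well with the open-chain ((tert-butoxycarbonyl)methyl)amino group, giving a 4.4-fold lower number from compound 1 to compound 3 (0.65 log units; beyond the scatter), so less compound is needed than with either earlier group. A five-membered ring at this place therefore does not by itself go with a high number, as compound 2 has the highest number of the three and compound 3 the lowest, and no measurement available here explains the difference.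

The ketone on the ring and the dimethylcarbamoyl group in place of the isopropoxycarbonyl group change together, so the compounds shown cannot say how much of the step belongs to each. Also open, on these data alone, is how this assay would respond to a carboxylic acid or a longer chain on the amide nitrogen in place of the dimethylcarbamoyl group.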